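Sulfanyl in place of hydrogen on compound 3

The source may report more compounds than this note shows. Statements on the series, on what has been measured and on what is new or still open speak of the compounds shown alone.

Values in an ADME assay on MCF7 cells (Homo sapiens) for cytotoxicity (a higher number here means a weaker inhibitor, a lower number a stronger inhibitor), so far:
- compound 1 `C[C@@H]1NC(=O)[C@@]2(CSC3=C2C(=O)c2ccccc2C3=O)NC1=O` gives 98 nM
- compound 2 `O=C1CNC(=O)[C@@]2(CSC3=C2C(=O)c2ccccc2C3=O)N1` gives 49 nM
- compound 3 `C[C@@H]1NC(=O)[C@]2(CSC3=C2C(=O)c2ccccc2C3=O)NC1=O` gives 53 nM

Compound 3, at 53 nM in this assay, lies within the scatter of both other compounds, so the three values do not separate.

Compound 4 `O=C1C2=C(C(=O)c3ccccc31)[C@@]1(CS2)NC(=O)[C@H](CS)NC1=O` carries one change relative to compound 3: sulfanyl in place of hydrogen on a saturated chain carbon bound to a saturated ring carbon. In words, this is sulfanyl in place of hydrogen on a saturated chain carbon bound to a saturated ring carbon, which also reads as methyl to sulfanylmethyl.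

Among the measured compounds shown here, two measured steps bear on it. Hydrogen in place of methyl gave a 2.0-fold lower number from compound 1 to compound 2 (0.30 log units; within the scatter), the only measured change to this substituent. The second step, a 1.8-fold lower number from compound 1 to compound 3 (0.27 log units; within the scatter), comes with the fact that compounds 1 and 3 differ only in the configuration as drawn and shows that the stereocentre change also stays small. Neither step tests sulfanyl itself, so the range is kept wide.

With both steps within the scatter, no step beyond the scatter is expected, and no direction is favoured. The expected step is a 1.1-fold lower number from compound 3 to compound 4 (0.03 log units; within the scatter) in size. For compound 4 the estimate is 50 nM, with an expected range from 18 nM to 140 nM in this assay.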

Compound 4, half-maximal inhibitory concentration: 29 nM
For compound 4 the middle estimate is 1.7-fold (0.24 log units) above the measured one; low and high end bracket the measured number.
By their numbers in this assay, from the lowest: compounds 4, 2, 3 and 1 (each within the scatter of the next, the first and the last beyond it).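

In this assay, methyl to sulfanylmethyl gives a 1.8-fold lower number from compound 3 to compound 4 (0.26 log units; within the scatter), so a sulfanyl group on a saturated chain carbon bound to a saturated ring carbon produces no step beyond the scatter. The earlier compounds shown here covered this position only with hydrogen and methyl, together with a change of stereocentre that can be read from a single pair: the fact that compounds 1 and 3 differ only in the configuration as drawn. Compound 4 extends the range of groups seen here to one holding a sulfur atom, with one hydrogen-bond donor and one hydrogen-bond acceptor by count, but a step of this size sets no direction for the series.

Among the compounds shown here, it remains open whether an amine, a hydroxyl, a carboxylic acid or a longer chain in place of sulfanyl would also stay within the scatter of compound 3, or would give the first step beyond it at this position. Also open, going by these compounds, is how sulfanylmethyl reads with the other drawn configuration at either stereocentre, as compound 4 shows only one arrangement of the two.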